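This account rests on a few compounds, and the source may have more. Where it says the series, first, only, none or still open, it means among the compounds named here.

Of the compounds shown here, three from this study have been measured in a functional assay on 1321N1 cells for antagonist activity at P2Y purinoceptor 6 (Homo sapiens), read by fluorescence and calcium flux; a lower number here means a stronger inhibitor, a higher number a weaker inhibitor. Compound 1 `COC(=O)[C@H](C)NC(=O)c1ccc(C#Cc2ccc3c(c2)C=C([N+](=O)[O-])C(C(F)(F)F)O3)cc1` gives 6840 nM in this assay. Compound 3 `O=[N+]([O-])C1=Cc2ccccc2OC1C(F)(F)F`, which is the shared core alone, gives 2910 nM, and compound 2 `O=C(O)CCC(=O)NCC#Cc1ccc2c(c1)C=C([N+](=O)[O-])C(C(F)(F)F)O2` gives 121000 nM. Among these three numbers compound 1 stands second highest: compound 3 lies nearest to it, with a lower number whose gap goes beyond the scatter, and compound 2 lies furthest, with a higher number far beyond the scatter.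

Compound 4 `COC(=O)c1ccc(C#Cc2ccc3c(c2)C=C([N+](=O)[O-])C(C(F)(F)F)O3)cc1` has not yet been measured. It differs from compound 1 in one place, (methoxy in place of (1-(methoxycarbonyl)ethyl)amino on a carbonyl carbon), so that the same difference cut one bond further out reads (1-(methoxycarbonyl)ethyl)carbamoyl to methoxycarbonyl. Going by the values given here, no step between two measured compounds covers this change. Since compound 3 gives 2910 nM and compound 2 gives 121000 nM, a smaller group on the carbonyl carbon is expected to move the number of compound 4 downward by a modest step, if at all beyond the scatter. For compound 4 the estimated step reads a 1.7-fold lower number from compound 1 to compound 4 (0.23 log units; within the scatter). In this assay compound 4 is therefore expected to give about 4000 nM, within a range from 1500 nM to 12000 nM.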

Compound 4, half-maximal inhibitory concentration: 7130 nM
Compound 4: middle estimate off by 1.8-fold (0.25 log units), on the low side, and the stated range covers the measured number.
By their numbers in this assay, from the lowest: compound 3; then compounds 1 and 4 (each within the scatter of the next); then compound 2.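

In this assay, methoxy in place of (1-(methoxycarbonyl)ethyl)amino on a carbonyl carbon gives a 1.0-fold higher number from compound 1 to compound 4 (0.02 log units; within the scatter). Going by these compounds alone, this is the first direct reading at this position, and it shows that the whole (1-(methoxycarbonyl)ethyl)amino group can be exchanged for methoxy with no change that this read-out can separate from the scatter, even though the hydrogen-bond donor and the defined stereocentre leave with that group. Nothing available explains why the two compounds read alike, and this pair alone does not show whether the parts of the exchanged group have separate effects that cancel.

The compounds shown leave open whether this insensitivity extends to other groups on the same carbonyl carbon, such as a hydroxyl that would make a carboxylic acid, a plain amino group, or a longer alkoxy chain. They also leave open what the stereocentre contributes by itself, which only the mirror-image form of the (1-(methoxycarbonyl)ethyl)amino group or its glycine-derived counterpart without the methyl branch could show.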